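The source may report more compounds than this note shows. Statements on the series, on what has been measured and on what is new or still open speak of the compounds shown alone.

Compound 1 `CCc1ccc(OCC(=O)Nc2cc(B(O)O)ccc2O)cc1`: 14900 nM
Compound 2 `O=C(COc1ccc(C2CCCCC2)cc1)Nc1cc(B(O)O)ccc1O`: 29200 nM

Both numbers come from a functional assay on HeLa cells (Homo sapiens) for inhibition, read by MTT assay, with a stated time of 48 h; a higher number here means a weaker inhibitor of growth, a lower number a stronger inhibitor of growth. Compound 2 has the highest of the two numbers, and its nearest neighbour is compound 1; the step of a 2.0-fold higher number from compound 1 to compound 2 (0.29 log units; within the scatter) lies within the scatter, so these two compounds cannot be told apart on this measurement. Compound 3 `CC(C)(C)c1ccc(OCC(=O)Nc2cc(B(O)O)ccc2O)cc1` is not yet measured in this assay. It differs from compound 2 in one place: tert-butyl in place of cyclohexyl on an aromatic carbon. The tert-butyl that enters has no ring and sits on the same aromatic carbon that carried the cyclohexyl, para to a large group. Among the measured compounds shown here, only one measured step bears on this change, the swap of ethyl for cyclohexyl at that carbon, and it stayed within the scatter. Since a small chain and a six-membered ring at this position gave numbers within the scatter of each other, the step of a 1.5-fold lower number from compound 2 to compound 3 (0.16 log units; within the scatter) is expected to stay within the scatter as well. Compound 3 is estimated at 20000 nM in this assay, with a range from 8000 nM to 50000 nM.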

Compound 3, concentration for 50% growth inhibition: 21300 nM
Estimate against measurement, compound 3: 1.1-fold (0.03 log units) below; the range from low to high includes it.
By their numbers in this assay, from the lowest: compounds 1, 3 and 2 (each within the scatter of the next).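

In this assay, tert-butyl gives a 1.4-fold lower number from compound 2 to compound 3 (0.14 log units; within the scatter) when it replaces cyclohexyl, and a 1.4-fold higher number from compound 1 to compound 3 (0.16 log units; within the scatter) when it replaces ethyl. Among the compounds shown here, three different groups have now been compared at this aromatic carbon, and no pair of them can be told apart on this measurement, whereas the earlier compounds offered only a single comparison. Neither removing the ring nor going from six heavy atoms in cyclohexyl to four in tert-butyl separates the compounds here, and no supporting information is available to explain this lack of separation.

From the compounds shown here alone, all three groups contain only carbon and hydrogen, so it remains open whether an amine, a carboxylic acid or a hydroxyl group on this carbon would move the number beyond the scatter. Going by these compounds, it is also open whether a much longer carbon chain at this place, or a change elsewhere on the shared core, would have a larger effect on growth inhibition than these swaps.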